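A few compounds are considered here, and "the series" means these few. Any claim that something is new, unique, unknown or untested is made for them only; others in the source may bear on it.

Of the compounds shown here, three have been read in a functional assay on MCF7 cells (Homo sapiens) for antiproliferative activity, read by MTT assay; a lower number here means a stronger inhibitor, a higher number a weaker inhibitor. Compound 1 `Cc1ccc(-n2cc(COc3ccc(/C=C/C(=O)c4cc5c(cc4O)OC(C)(C)CC5)cc3)nn2)cc1Br` is reported as "not active" (no number reported), and compound 3 `CC1(C)CCc2cc(C(=O)/C=C/c3ccc(OCc4cn(Cc5ccc([N+](=O)[O-])cc5)nn4)cc3)c(O)cc2O1` is also reported as "not active" (no number reported). Among the compounds with values here, compound 2 `Cc1c(-n2cc(COc3ccc(/C=C/C(=O)c4ccc5c(c4O)CCC(C)(C)O5)cc3)nn2)cccc1[N+](=O)[O-]` gives 145000 nM, the only number in the set, so there is no measured step against which to scale a change.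

Compound 4 `CC1(C)CCc2c(ccc(C(=O)/C=C/c3ccc(OCc4cn(Cc5ccc([N+](=O)[O-])cc5)nn4)cc3)c2O)O1` has not yet been measured. Its difference from compound 2 is 4-nitrobenzyl in place of 2-methyl-3-nitrophenyl on an aromatic nitrogen. The same 4-nitrobenzyl group is carried by compound 3, which is reported as "not active" (no number reported), so a result without a number is a real possibility for compound 4.

If a number is obtained, no change beyond the scatter is expected in this assay. The estimated step of a 1.1-fold higher number from compound 2 to compound 4 (0.04 log units; within the scatter) is therefore expected to be small. Compound 4 is estimated at 160000 nM, with an expected range of 70000 nM to 350000 nM.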

Compound 4, half-maximal inhibitory concentration: 17100 nM
For compound 4 the middle estimate is 9.4-fold (0.97 log units) above the measured one; measured number outside the range, below it.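

In this assay, within the data shown here, the group on the aromatic nitrogen affects the read-out even when the atom count stays the same: 4-nitrobenzyl in place of 2-methyl-3-nitrophenyl gives an 8.5-fold lower number from compound 2 to compound 4 (0.93 log units; beyond the scatter), the first measured step. The 4-nitrobenzyl group alone therefore does not rule out a numerical result: compound 4 gives a number, whereas compound 3, which differs from it in the arrangement of the core, is reported as "not active" (no number reported). Nothing at hand accounts for the step.

From the compounds shown here alone, the methyl group, the place of the nitro group and the link to the aromatic nitrogen all change together in this one swap, so their separate contributions stay open. Plain benzyl, or an amine or carboxylic acid in place of the nitro group, would help to separate them.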